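Adding a Second Fluoro to Compound 2: Cytotoxicity Expectation

This account rests on a few compounds, and the source may have more. Where it says the series, first, only, none or still open, it means among the compounds named here.

Measured so far:
- Compound 1, `Cc1c(C(=O)NCc2ccccc2)[n+]([O-])c2ccccc2[n+]1[O-]`, gives > 100 ug/mL in an ADME assay on Vero cells (Chlorocebus sabaeus) for cytotoxicity, read by MTT assay, with a stated time of 72 h (on this read-out lower numbers stand for stronger inhibition and higher numbers for weaker inhibition), which is a limit of the assay.
- Compound 2, `Cc1c(C(=O)NCc2ccccc2)[n+]([O-])c2cc(F)ccc2[n+]1[O-]`, gives > 100 ug/mL in this assay, again a limit.

Compound 2 thus stands at the upper limit of this assay, with no number resolved. Compound 3, `Cc1c(C(=O)NCc2ccccc2)[n+]([O-])c2cc(F)c(F)cc2[n+]1[O-]`, differs from compound 2 by fluoro in place of hydrogen on an aromatic carbon. Within the data shown here, the one measured step of the same kind, a step that the two limits leave unreadable from compound 1 to compound 2, has no readable size because both of its ends sit at the limit of > 100 ug/mL in this assay, at which 2 of the 2 values shown sit. Compound 3 is therefore expected to show no step beyond the scatter, a step that the limit leaves unreadable from compound 2 to compound 3. Compound 3 is estimated in this assay at 150 ug/mL, within 70 ug/mL to 400 ug/mL, most likely reported again only as a limit.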

Compound 3, half-maximal inhibitory concentration: 18.4 ug/mL
For compound 3 the middle estimate is 8.2-fold (0.91 log units) above the measured one; measured number outside the range, below it.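

In this assay, fluoro in place of hydrogen on this aromatic carbon, ortho to a fluoro group, comes with an at least 5.4-fold lower number from compound 2 to compound 3 (0.73 log units; beyond the scatter). Among these compounds, this shows that a change of this kind can bring a value within the measurable range, which the earlier compounds did not show. The step from compound 1 to compound 2 cannot be read, so only this fluoro step has a size: the limit of > 100 ug/mL in this assay, at which 2 of the 3 values shown sit.

From the compounds shown here alone, whether a fluoro on this carbon would lower the number without the other fluoro remains open. So does whether a chloro or a methoxy group here would do the same.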